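The source may report more compounds than this note shows. Statements on the series, on what has been measured and on what is new or still open speak of the compounds shown alone.

For the measured compounds named here, compound 3 `COc1ccc(-c2cc3ccccc3nc2/C=C/C(=O)c2c(OC)cccc2OC)cc1` gives 4470 nM in a functional assay on H184B5F5/M10 cells (Homo sapiens) for antiproliferative activity, read by XTT assay, with a stated time of 72 h (a lower number here means a stronger inhibitor, a higher number a weaker inhibitor), the only number reported among the three measured compounds. Compound 1 `COc1ccc(-c2cc3ccccc3nc2C=O)cc1` reaches only a limit of the assay, > 10000 nM. Compound 2 `COc1ccc(C(=O)/C=C/c2nc3ccccc3cc2-c2ccc(OC)cc2)cc1` likewise reaches only a limit, > 10000 nM. Compound 4 `COc1ccc(-c2cc3ccccc3nc2/C=C/C(=O)c2ccc(N)cc2)cc1` differs from compound 3 by 4-aminophenyl in place of 2,6-dimethoxyphenyl on a carbonyl carbon. Going by the values given here, the single measured step at this carbonyl-attached ring, an at least 2.2-fold lower number from compound 2 to compound 3 (0.34 log units; beyond the scatter), is the only guide, and its true size is uncertain because the limit of > 10000 nM in this assay, at which 2 of the 3 values shown sit, hides how far compound 2 lies. Since compound 4 carries a singly substituted ring, as the 4-methoxyphenyl of compound 2 did, a weaker result than compound 3 is expected, roughly a 1.8-fold higher number from compound 3 to compound 4 (0.25 log units; within the scatter). Compound 4 is therefore estimated at 8000 nM, within 2500 nM to 30000 nM.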

Compound 4, half-maximal inhibitory concentration: 9290 nM
Beside the measured number, compound 4's estimate is 1.2-fold (0.06 log units) below it; the range from low to high includes it.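

For the compounds shown here, at this carbonyl carbon, two measured numbers can now be compared for the first time in this assay, and 4-aminophenyl in place of 2,6-dimethoxyphenyl gives a 2.1-fold higher number from compound 3 to compound 4 (0.32 log units; beyond the scatter). So the 2,6-dimethoxyphenyl ring of compound 3 keeps a modest edge over a ring with a single substituent. Amino in place of methoxy on an aromatic carbon gives an at least 1.0-fold lower number from compound 2 to compound 4 (0.03 log units; that floor lies within the scatter), and the true size of that step stays hidden because of a ceiling: the limit of > 10000 nM in this assay, at which 2 of the 4 values shown sit.

The compounds shown leave open how a ring carrying chlorine, a dimethylamino group or a carboxylic acid would fare at this carbonyl carbon. They also leave open whether a ring with one methoxy group kept from compound 3 would match it.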